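Trifluoromethyl for methoxy on the aryl ring of compound 1

The source may report more compounds than this note shows. Statements on the series, on what has been measured and on what is new or still open speak of the compounds shown alone.

Of the compounds shown here, two sharing one core have been measured in a functional assay on the whole organism (strain Swiss) with Mus musculus as the target, in the maximal electroshock model, with a stated time of 0.25 h, at a dose of 100 mg/kg by the intraperitoneal route; on this read-out lower numbers stand for a weaker effect and higher numbers for a stronger effect at the one dose given. Compound 1 `COc1cccc(N2CCN(C(=O)C(C)N3C(=O)CCC3=O)CC2)c1` gives 25% in this assay and stands lowest of the two numbers shown. Compound 2 `CC(C(=O)N1CCN(c2ccc(Cl)cc2)CC1)N1C(=O)CCC1=O` gives 50% in this assay. For the measured compounds named here, the only measured step is a number 25 percentage points higher from compound 1 to compound 2 (beyond the scatter), a change in which the methoxy-bearing ring of compound 1 is exchanged for a 4-chlorophenyl.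

Compound 3 `CC(C(=O)N1CCN(c2cccc(C(F)(F)F)c2)CC1)N1C(=O)CCC1=O` is not yet measured. It differs from compound 1 as follows: trifluoromethyl in place of methoxy on an aromatic carbon. The step from compound 1 to compound 2 bears on this change only loosely, since it removes the methoxy but places a halogen at a different position, whereas compound 3 keeps the same position and puts a trifluoromethyl there. Going by the values given here, that step was of modest size and upward; by analogy a modest upward step is expected here too, but with less confidence because the single comparison available is imperfect. The step expected for this assay is a number 15 percentage points higher from compound 1 to compound 3 (beyond the scatter). Compound 3 is therefore estimated at 40% in this assay, with a range from 20% to 65%.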

Compound 3, a percentage reported as activity, at one dose (the size of the read-out at that dose, not a potency): 50%
Beside the measured number, compound 3's estimate is 10 percentage points below it, within the range that was stated.
By their numbers in this assay, from the lowest: compound 1; then compounds 2 and 3 (each within the scatter of the next).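

In this assay the exchange of methoxy for trifluoromethyl, on an aromatic carbon meta to a large group, gives a number 25 percentage points higher from compound 1 to compound 3 (beyond the scatter) for this one change. The earlier step, a number 25 percentage points higher from compound 1 to compound 2 (beyond the scatter) when 4-chlorophenyl takes the place of 3-methoxyphenyl, altered both the group and its place on the ring, so it could not show what this place tolerates. Here the place stays the same and only the group differs, which shows that a higher number at this dose can be reached without moving the substituent. No measurement shown here explains why the exchange gives this step.

The compounds shown leave open whether chlorine, an amine or a carboxylic acid at this same place would give a similar number, and whether trifluoromethyl would keep it at the place that chlorine holds in compound 2. On these data alone, each number is also the size of the effect at one dose and one stated time, so how these compounds rank in potency stays unknown in this assay as well.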